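Swapping the Indole of Compound 1 for a Trihydroxyphenyl

This account rests on a few compounds, and the source may have more. Where it says the series, first, only, none or still open, it means among the compounds named here.

Compound 1, with structure `Cc1ccc(CS/C(=C/c2c[nH]c3ccc(Cl)cc23)C(=O)c2ccc(Cl)cc2)cc1`, was tested in a functional assay on DU-145 cells (Homo sapiens) for inhibition, read by trypan blue exclusion, with a stated time of 96 h (on this read-out lower numbers stand for stronger inhibition of growth and higher numbers for weaker inhibition of growth), where compound 1 gives 1000 nM. Compound 3, `O=C(/C(=C\c1ccc(OCc2ccccc2)cc1)SCc1ccc(Cl)cc1)c1ccc(Cl)cc1`, shows the same number at the digits shown, since compound 3 gives 1000 nM; together these are the lowest of the three values. Compound 2, `Cc1ccc(CS(=O)(=O)/C(=C/c2ccc(N(C)C)cc2)C(=O)c2ccc(Cl)cc2)cc1`, stands furthest away, as compound 2 gives 50000 nM. The unmeasured compound 4, `Cc1ccc(CS/C(=C/c2c(O)cc(O)cc2O)C(=O)c2ccc(Cl)cc2)cc1`, differs from compound 1 in one place: 2,4,6-trihydroxyphenyl in place of 5-chloro-1H-indol-3-yl on a double-bonded chain carbon bound to a double-bonded chain carbon. Within the data shown here, no measured pair shows this change, so the expectation rests on compound 1 alone. A step toward a higher number, beyond the usual scatter, is expected: the estimated step from compound 1 to compound 4 is a 5.0-fold higher number from compound 1 to compound 4 (0.70 log units; beyond the scatter). Compound 4 is therefore expected to give 5000 nM, within 1000 nM to 30000 nM.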

Compound 4, concentration for 50% growth inhibition: 50000 nM
Compound 4: middle estimate off by 10-fold (1.00 log units), on the low side, and the stated range ends below it.
By their numbers in this assay, from the lowest: compounds 1 and 3 (each within the scatter of the next); then compounds 2 and 4 (each within the scatter of the next).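

In this assay, putting 2,4,6-trihydroxyphenyl in place of 5-chloro-1H-indol-3-yl gives a 50-fold higher number from compound 1 to compound 4 (1.70 log units; beyond the scatter), so the group on this double-bonded chain carbon strongly affects the read-out. The earlier compounds shown here differ in more than one place and could not isolate this position. Nothing available explains the size of this step.

Still open, as far as these compounds go, is whether the step follows from losing the 5-chloro-1H-indol-3-yl or from gaining the hydroxyl groups. A plain phenyl or a 2,4,6-trimethoxyphenyl at this place would help separate those two readings.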